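Hydroxy additions on a styrylchromone-type series

A few compounds are considered here, and "the series" means these few. Any claim that something is new, unique, unknown or untested is made for them only; others in the source may bear on it.

Measured so far:
- compound 1, `O=c1cc(/C=C/c2ccc(O)cc2)oc2cc(O)ccc12`: 1650 nM
- compound 2, `O=c1cc(/C=C/c2ccc(O)c(O)c2)oc2cc(O)ccc12`: 610 nM
- compound 3, `O=c1cc(/C=C/c2ccc(O)c(O)c2)oc2ccccc12`: 440 nM

In a functional assay, in the presence of a further agent that is not named here (on this read-out higher numbers stand for weaker inhibition and lower numbers for stronger inhibition), compound 1 gives the highest of the three numbers; compound 2 stands nearer to it and compound 3 furthest away, both beyond the scatter. Compound 4, `O=c1cc(/C=C/c2ccc(O)cc2)oc2cc(O)cc(O)c12`, differs from compound 1 by hydroxy in place of hydrogen on an aromatic carbon. For the measured compounds named here, two measured steps bear on this. The step of a 2.7-fold lower number from compound 1 to compound 2 (0.43 log units; beyond the scatter) also adds a hydroxy, but on the other aromatic ring of the shared core, so it speaks only indirectly. The step of a 1.4-fold lower number from compound 2 to compound 3 (0.14 log units; within the scatter) removes a hydroxy from the same fused ring that is changed here and stays within the scatter; it is the closer parallel. On that basis the addition in compound 4 is expected to bring no step beyond the scatter in this assay, with the estimated shift being a 1.2-fold lower number from compound 1 to compound 4 (0.07 log units; within the scatter). The value for compound 4 is therefore estimated at 1400 nM, within a range from 600 nM to 3300 nM.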

Compound 4, half-maximal inhibitory concentration: 1210 nM
Beside the measured number, compound 4's estimate is 1.2-fold (0.06 log units) above it, within the range that was stated.
By their numbers in this assay, from the lowest: compounds 3, 2, 4 and 1 (each within the scatter of the next, the first and the last beyond it).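

In this assay, hydroxy in place of hydrogen at this position, on a ring that is part of the fused system and meta to a hydroxy group, gives a 1.4-fold lower number from compound 1 to compound 4 (0.13 log units; within the scatter). Read in the reverse direction, as hydrogen in place of hydroxy, the change can now be compared on two cores, and the two steps agree: the same change on two cores in this assay, a 1.4-fold lower number (0.14 log units; within the scatter) from compound 2 to compound 3 and a 1.4-fold higher number (0.13 log units; within the scatter) from compound 4 to compound 1, 1.9-fold (0.28 log units) apart, within the scatter of two such steps Across the compounds shown, neither change on the fused system moves the number beyond the scatter, whereas the one single-place step beyond it, a 2.7-fold lower number from compound 1 to compound 2 (0.43 log units; beyond the scatter), lies on the other aromatic ring.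

On these data alone, it remains open whether a methoxy group or an amine at this position would behave as hydroxy does. Also open, as far as these compounds go, is whether the same addition stays this small on the core of compound 2.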